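A Methyl on a Nitrogen of Compound 1

The source may hold more compounds than are shown below. What is called first, only, known or untested is meant among the compounds shown, and "the series" means these compounds.

In a functional assay on DU-145 cells (Homo sapiens) for antiproliferative activity, read by sulforhodamine B assay, with a stated time of 48 h (a lower number here means a stronger inhibitor of growth, a higher number a weaker inhibitor of growth), compound 1 `COc1ccc(Nc2nc(NCCCO)c3ccccc3n2)cc1` gives 18300 nM and so sits within the scatter of both its measured relatives, compound 2 `CNc1nc(Nc2ccc(OC)cc2)nc2ccccc12` at 14300 nM and compound 3 `COc1ccc(Nc2nc(NC3CC3)c3ccccc3n2)cc1` at 13000 nM in the same series.

Compound 4 `COc1ccc(N(C)c2nc(NCCCO)c3ccccc3n2)cc1` departs from compound 1 in one place: methyl in place of hydrogen on a nitrogen on an aromatic ring.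

Among the measured compounds shown here, no measured step touches that nitrogen. All three change the group on a different nitrogen, which leaves only indirect evidence. Those changes gave a 1.3-fold lower number from compound 1 to compound 2 (0.11 log units; within the scatter), then a 1.4-fold lower number from compound 1 to compound 3 (0.15 log units; within the scatter), and finally a 1.1-fold lower number from compound 2 to compound 3 (0.04 log units; within the scatter), and each of these lies within the scatter. The numbers in this small set have so far stayed close together, yet they say nothing direct about replacing this particular hydrogen.

Going by these compounds, the expectation in this assay is therefore no step beyond the scatter, held with a wide margin since the site is untested. The estimated step is a 1.2-fold lower number from compound 1 to compound 4 (0.09 log units; within the scatter) on this reasoning. For compound 4 the expected value is 15000 nM, with an estimated range from 5000 nM to 40000 nM for the measurement.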

Compound 4, concentration for 50% growth inhibition: 30200 nM
For compound 4 the middle estimate is 2.0-fold (0.30 log units) below the measured one; the range from low to high includes it.
By their numbers in this assay, from the lowest: compounds 3, 2, 1 and 4 (each within the scatter of the next, the first and the last beyond it).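

Among the compounds shown here, the earlier compounds changed only the group on the other nitrogen, so compound 4 gives the first reading at this nitrogen on an aromatic ring. In this assay, putting methyl, a single carbon, in place of the hydrogen gives a 1.7-fold higher number from compound 1 to compound 4 (0.22 log units; within the scatter), so in this one pair, the hydrogen on this nitrogen is not needed to keep the number within the scatter of compound 1. Nothing measured here offers an explanation for this result.

This single pair says nothing about whether an ethyl group, an acetyl group or a longer chain on the same nitrogen would also stay within the scatter, since methyl adds only 1 heavy atom and a larger group might behave differently. It also leaves open whether methyl on this nitrogen would give a similar step with the methyl of compound 2 or the cyclopropyl of compound 3 on the other nitrogen in place of the 3-hydroxypropyl chain of compound 1.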